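The source may report more compounds than this note shows. Statements on the series, on what has been measured and on what is new or still open speak of the compounds shown alone.

Compound 1, `O=C1c2c[n+]([O-])c3ccccc3c2C(=O)c2c1c1ccccc1n2Cc1cn(C[C@H](O)CO)nn1`, gives 400 nM in a functional assay on HCT-116 cells (Homo sapiens) for cytotoxicity, read by MTT assay, with a stated time of 72 h (on this read-out lower numbers stand for stronger inhibition and higher numbers for weaker inhibition), the highest of the two numbers recorded so far. Its nearest neighbour, compound 2, `CC1(C)OC[C@@H](Cn2cc(Cn3c4c(c5ccccc53)C(=O)c3c[n+]([O-])c5ccccc5c3C4=O)nn2)O1`, gives 340 nM in this assay, and the step of a 1.2-fold lower number from compound 1 to compound 2 (0.07 log units; within the scatter) is within the scatter. Among the measured compounds shown here, that is the only measured step, and it bears on compound 3, `CN1CCN(CCCCCCn2c3c(c4ccccc42)C(=O)c2c[n+]([O-])c4ccccc4c2C3=O)CC1`, only loosely: it shows that a change on the same saturated chain carbon bound to an aromatic nitrogen left the shared core much as it was, but the change from compound 1 to compound 3 is of a different kind, (5-(4-methylpiperazin-1-yl)pentyl in place of 1-(2,3-dihydroxypropyl)-1H-1,2,3-triazol-4-yl on a saturated chain carbon bound to an aromatic nitrogen). For the measured compounds named here, no measured pair shows a swap of that size at this place, so the direction of any step cannot be read from the data. Given that the one variation at this position, from compound 1 to compound 2, stayed within the scatter, the step of a 1.1-fold lower number from compound 1 to compound 3 (0.06 log units; within the scatter) is estimated to be modest as well. Compound 3 is accordingly expected to give about 350 nM in this assay, within a range from 100 nM to 1200 nM.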

Compound 3, half-maximal inhibitory concentration: 2900 nM
Estimate against measurement, compound 3: 8.3-fold (0.92 log units) below; measured number outside the range, above it.
By their numbers in this assay, from the lowest: compounds 2 and 1 (each within the scatter of the next); then compound 3.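

In this assay, the place on a saturated chain carbon bound to an aromatic nitrogen turns out not to be indifferent to what it carries: a 7.3-fold higher number from compound 1 to compound 3 (0.86 log units; beyond the scatter), whereas a 1.2-fold lower number from compound 1 to compound 2 (0.07 log units; within the scatter) had left the number within the scatter. The earlier pair had altered only the 1,2-dihydroxyethyl end of the substituent, while here the whole 1-(2,3-dihydroxypropyl)-1H-1,2,3-triazol-4-yl group gives way to 5-(4-methylpiperazin-1-yl)pentyl, and this larger exchange brings weaker inhibition on this read-out. No measurement at hand accounts for the step.

The compounds shown leave open which part of the exchange goes with the step, as the triazole ring and the dihydroxypropyl part leave together while the pentyl chain and the methylpiperazine ring enter together. A plain hexyl chain, a shorter chain ending in the same 4-methylpiperazin-1-yl ring, or a morpholine ring on the pentyl chain would each pull these parts apart, and the same holds for a triazole ring carrying a methylpiperazine.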